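A few compounds are considered here, and "the series" means these few. Any claim that something is new, unique, unknown or untested is made for them only; others in the source may bear on it.

Compound 2 `COc1cc2nnc(C(N)=O)c(Nc3ccc(C)cc3F)c2cc1N1CCC(N(C)C)CC1` gives 2.2 L/kg in an ADME assay on the whole organism for pharmacokinetics, with Rattus norvegicus as the target (on this read-out higher numbers stand for wider distribution into tissues and lower numbers for narrower distribution), and stands within the scatter of compound 1 `COc1cc2nnc(C(N)=O)c(Nc3ccc(C)cc3F)c2cc1N1CCN(C)CC1`, which gives 3.8 L/kg. Among the compounds with values here, the one measured step, a 1.7-fold lower number from compound 1 to compound 2 (0.24 log units; within the scatter), did not leave the scatter. Compound 3 `COc1cc2nnc(C(N)=O)c(Nc3ccc(C)cc3F)c2cc1N1CCC(OC)CC1` differs from compound 2 by methoxy in place of dimethylamino on a saturated ring carbon. Within the data shown here, no measured pair shows this exchange, so the expectation rests on that single step only; a shift at the edge of the scatter is expected, a 1.5-fold lower number from compound 2 to compound 3 (0.17 log units; within the scatter) by this estimate. Compound 3 is accordingly expected to give 1.5 L/kg, with a range from 0.8 L/kg to 2.8 L/kg in this assay.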

Compound 3, volume of distribution at steady state: 1.8 L/kg
Compound 3: middle estimate off by 1.2-fold (0.08 log units), on the low side, within the range that was stated.
By their numbers in this assay, from the lowest: compounds 3, 2 and 1 (each within the scatter of the next, the first and the last beyond it).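

In this assay, methoxy and dimethylamino on the saturated ring carbon cannot be told apart (a 1.2-fold lower number from compound 2 to compound 3 (0.09 log units; within the scatter)). Within the data shown here, the change of the whole group does separate the compounds, though only modestly (a 2.1-fold lower number from compound 1 to compound 3 (0.32 log units; beyond the scatter)): 4-methoxypiperidin-1-yl is the first replacement of 4-methylpiperazin-1-yl here to leave the scatter. Nothing available explains either step. Still open, going by these compounds, is how an amine, a carboxylic acid or a longer alkoxy chain on that ring carbon would read, and whether a hydroxyl would stay within the scatter of compound 3.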